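A few compounds are considered here, and "the series" means these few. Any claim that something is new, unique, unknown or untested is made for them only; others in the source may bear on it.

Compound 1 `Cc1ccc(-c2nc(CNc3ccc(C(=O)NO)cc3)n(-c3ccccc3)n2)cc1` gives little to measure from. In a functional assay on MGC-803 cells (Homo sapiens) for antiproliferative activity, read by MTT assay, with a stated time of 72 h (a higher number here means a weaker inhibitor, a lower number a stronger inhibitor), compound 1 gives > 20000 nM, which is a limit of the assay and not a number. That places compound 1 at the limit of > 20000 nM in this assay, at which 1 of the 2 values shown sits. Compound 2 `COc1ccc(-n2nc(-c3ccccc3)nc2CNc2ccc(C(=O)NO)cc2)cc1`, the other measured compound, gives an actual number of 7050 nM in this assay.

Compound 3 `O=C(NO)c1ccc(NCc2nc(-c3cccc(Cl)c3)nn2-c2ccccc2)cc1` keeps the core of compound 1 and changes a single group: it has 3-chlorophenyl in place of 4-methylphenyl on an aromatic carbon, between two ring nitrogen atoms (3-chlorophenyl in place of 4-methylphenyl on an aromatic carbon). Going by the values given here, no measured step shows what a swap of this kind does, so any forecast here is rough. Among the compounds with values here, the one guide is compound 2 at 7050 nM, which shows that a close relative of compound 1 can give a number in this assay. A modest move toward stronger inhibition is expected, perhaps none beyond the scatter, and the estimated change is an at least 1.4-fold lower number from compound 1 to compound 3 (0.15 log units; that floor lies within the scatter). A result that again reaches only the limit would be no surprise. The estimate for compound 3 is 14000 nM, with an expected range from 5000 nM to 35000 nM.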

Compound 3, half-maximal inhibitory concentration: 5760 nM
Compound 3: the middle estimate sits 2.4-fold (0.39 log units) above what was measured; the range from low to high includes it.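

In this assay, going by these compounds alone, putting 3-chlorophenyl in place of 4-methylphenyl on an aromatic carbon, between two ring nitrogen atoms, gives an at least 3.4-fold lower number from compound 1 to compound 3 (0.54 log units; beyond the scatter), the first measured step at this position. It shows that the group on this carbon can change the antiproliferative read-out, even though the two groups have the same count of 7 heavy atoms and each holds one six-membered aromatic ring of carbon only. Compound 1 gives a limit and not a number, so the true size of the step stays unknown and only its minimum can be read: the limit of > 20000 nM in this assay, at which 1 of the 3 values shown sits.

This swap changes both the substituent on the phenyl ring and where it sits, and the compounds shown do not separate those two changes. A 3-methylphenyl or a 4-chlorophenyl group on this carbon would tell them apart, while a 3-aminophenyl group would show how a substituent of a different kind behaves at this position.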